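The compounds below may be only part of what the source reports. "The series", "measured", "known", "first", "only" and "open" are said of these compounds alone.

Working notes on the series. Compound 1 `COc1ccc(Cl)cc1N(CC(=O)Nc1ccc(C(F)(F)F)cc1)S(=O)(=O)c1ccccc1` gives 3750 nM in a functional assay on SH-SY5Y cells (Homo sapiens), read by MTT assay, with a stated time of 24 h; on this read-out lower numbers stand for an effect already at smaller amounts and higher numbers for an effect only at larger amounts of compound. Compound 2 `COc1ccc(NC(=O)CN(c2cc(Cl)ccc2OC)S(=O)(=O)c2ccccc2)cc1` gives 16200 nM in this assay, and the step is a 4.3-fold higher number from compound 1 to compound 2 (0.64 log units; beyond the scatter). Compound 3 `CCN(CC)C(=O)CN(c1cc(Cl)ccc1OC)S(=O)(=O)c1ccccc1` is recorded in this assay only as a limit, > 20000 nM. A value of this kind is described as the limit of > 20000 nM in this assay, at which 1 of the 3 values shown sits. Compound 3 thus stands at the top edge of the numbers shown, with the steps of an at least 5.3-fold higher number from compound 1 to compound 3 (0.72 log units; beyond the scatter) and an at least 1.2-fold higher number from compound 2 to compound 3 (0.09 log units; that floor lies within the scatter) leading to it. Compound 4 `COc1cccc(NC(=O)CN(c2cc(Cl)ccc2OC)S(=O)(=O)c2ccccc2)c1` differs from compound 3 by (3-methoxyphenyl)amino in place of diethylamino on a carbonyl carbon. This change undoes the kind of replacement that went from compound 2 to compound 3, now carrying a 3-methoxyphenyl rather than the 4-methoxyphenyl of compound 2. Both measured steps toward compound 3 ran to higher numbers, so a step toward lower numbers is expected here, of a size between those two steps. Compound 4 is expected at 12000 nM, with a range from 4000 nM to 30000 nM. The expected step is an at least 1.6-fold lower number from compound 3 to compound 4 (0.22 log units; that floor lies within the scatter).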

Compound 4, half-maximal effective concentration: 17600 nM
The estimate for compound 4 lay 1.5-fold (0.17 log units) below the measured number; the measured number falls inside the stated range.
By their numbers in this assay, from the lowest: compound 1; then compounds 2 and 4 (each within the scatter of the next). At a limit, above all of these: compound 3.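

In this assay, the methoxy group's place on the ring of the amide-type nitrogen makes no readable difference: 3-methoxyphenyl in place of 4-methoxyphenyl gives a 1.1-fold higher number from compound 2 to compound 4 (0.04 log units; within the scatter). The 4-(trifluoromethyl)phenyl group stays apart from this methoxy isomer as well, at a 4.7-fold higher number from compound 1 to compound 4 (0.67 log units; beyond the scatter). Replacing diethylamino on the carbonyl carbon can be read only as a floor, an at least 1.1-fold lower number from compound 3 to compound 4 (0.05 log units; that floor lies within the scatter), and the number it starts from is a limit: the limit of > 20000 nM in this assay, at which 1 of the 4 values shown sits.

On these data alone, whether trifluoromethyl keeps its lower number when carried as 3-(trifluoromethyl)phenyl remains open, as does what a plain phenyl or a 4-cyanophenyl would give on the amide-type nitrogen. As far as these compounds go, a cyclic amine such as piperidine on the carbonyl carbon also remains open.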